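From phenyl to thiophen-2-yl on a shared core

The compounds below may be only part of what the source reports. "The series", "measured", "known", "first", "only" and "open" are said of these compounds alone.

Measured so far in a physicochemical assay for lipophilicity, measured as octanol-water partition; a lower number here means a more polar compound, a higher number a more lipophilic compound
- compound 1 `COc1ccc2c(c1)[n+]([O-])c(C#N)c(-c1ccc(OC(F)(F)F)cc1)[n+]2[O-]` gives 1.33
- compound 2 `COc1ccc2c(c1)[n+]([O-])c(C#N)c(-c1ccccc1)[n+]2[O-]` gives 1.58

Compound 2, with its plain phenyl group, stands level with compound 1 once the usual scatter is allowed for. Among the measured compounds shown here, the only measured step is a number 0.25 log units higher from compound 1 to compound 2 (within the scatter) and it spans the whole range seen so far.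

In compound 3 `COc1ccc2c(c1)[n+]([O-])c(C#N)c(-c1cccs1)[n+]2[O-]` the phenyl ring itself is exchanged thiophen-2-yl in place of phenyl on an aromatic carbon and the thiophen-2-yl group sits on the same carbon, next to the ring nitrogen and ortho to a cyano group. The measured step bears on this only loosely. For the measured compounds named here, it changed a group carried on the phenyl ring, not the ring itself, and no measured compound holds thiophen-2-yl. Going by the values given here, still, with a number 0.25 log units higher from compound 1 to compound 2 (within the scatter) as the sole guide, only a small shift is expected, perhaps slightly downward. Expected in this assay is a number 0.18 log units lower from compound 2 to compound 3 (within the scatter) as an estimated step that stays within the scatter. For compound 3 the estimated value is 1.4 (expected range 1 to 1.8).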

Compound 3, partition coefficient: 1.11
The estimate for compound 3 lay 0.29 log units above the measured number, and the stated range covers the measured number.
By their numbers in this assay, from the lowest: compounds 3, 1 and 2 (each within the scatter of the next, the first and the last beyond it).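

Exchanging the ring itself on this aromatic carbon, with thiophen-2-yl in place of phenyl, changes the reading in this assay by more than the earlier change did: the result is a number 0.47 log units lower from compound 2 to compound 3 (beyond the scatter). Among the compounds shown here, the only earlier step, a number 0.25 log units higher from compound 1 to compound 2 (within the scatter), altered a group carried on the phenyl ring and left the ring in place, so this is the first step to pass beyond the scatter, although it is still a modest one. The results give the size and direction of this shift, but nothing shown here accounts for it.

This reading rests on a single pair of compounds, so it cannot yet be said whether the drop belongs to thiophen-2-yl alone or would also appear with another ring on the same carbon, such as thiophen-3-yl, furan-2-yl or a pyridine ring. Going by these compounds, it is also open whether trifluoromethoxy or an amine carried on the thiophene ring would shift the number as little as trifluoromethoxy did on the phenyl ring.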